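The source may report more compounds than this note shows. Statements on the series, on what has been measured and on what is new or still open speak of the compounds shown alone.

Compounds measured so far in a functional assay on the whole organism (strain Wistar albino) for inhibition, with Rattus norvegicus as the target, read by paw edema, with a stated time of 3 h, at a dose of 25 mg/kg by the oral route; on this read-out lower numbers stand for less inhibition and higher numbers for more inhibition at the one dose given (going by the name of the read-out):
- compound 1, `Cc1ccc(Nc2nn(-c3ccc(S(N)(=O)=O)cc3)c3nc(Nc4ccccc4)n(-c4ccccc4)c(=O)c23)cc1`, gives 43.7%
- compound 2, `O=c1c2c(Nc3ccc(Cl)cc3)nn(-c3ccc([N+](=O)[O-])cc3)c2nc(Nc2ccccc2)n1-c1ccccc1`, gives 20.6%

Of the two numbers, compound 2 stands at the lower one, and its nearest neighbour is compound 1, whose value lies beyond the usual scatter above it. Compound 3, `NS(=O)(=O)c1ccc(-n2nc(Nc3ccc(Cl)cc3)c3c(=O)n(-c4ccccc4)c(Nc4ccccc4)nc32)cc1`, has not yet been measured. It differs from compound 2 in a single place: sulfamoyl in place of nitro on an aromatic carbon. For the measured compounds named here, no step between two measured compounds isolates this change alone, since compound 1 and compound 2 differ in more than one place, so the two values shown can only hint at its size. Taking the higher value of compound 1 as an indication, compound 3 is expected to sit above compound 2, with an estimated step of a number 17.4 percentage points higher from compound 2 to compound 3 (beyond the scatter) that goes beyond the scatter. On that basis compound 3 is estimated at 38%, within a range from 24% to 52%.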

Compound 3, a percentage reported as inhibition, in the whole organism at one dose (the size of the read-out at that dose, not a potency): 38.3%
Compound 3: the middle estimate sits 0.3 percentage points below what was measured; low and high end bracket the measured number.
By their numbers in this assay, from the lowest: compound 2; then compounds 3 and 1 (each within the scatter of the next).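

In this assay, the change from 4-nitrophenyl to 4-sulfamoylphenyl can now be read on its own, with the rest of the structure held constant: a number 17.7 percentage points higher from compound 2 to compound 3 (beyond the scatter) is the size of this change at this place on the ring. The second single change, chloro in place of methyl on an aromatic carbon, gives a number 5.4 percentage points lower from compound 1 to compound 3 (within the scatter) and so does not separate the two compounds when sulfamoyl is present. Nothing available explains why sulfamoyl and nitro differ here.

Going by these compounds, it remains open whether another group at this place, such as a carboxylic acid, a methylsulfonyl group or a simple amine, would match sulfamoyl or nitro. On these data alone, it is also open whether chloro and methyl would remain indistinguishable with nitro in place of sulfamoyl.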